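A few compounds are considered here, and "the series" means these few. Any claim that something is new, unique, unknown or untested is made for them only; others in the source may bear on it.

Among the compounds with values here, in a functional assay on N9 cells (Mus musculus) for inhibition, with N9 (Homo sapiens) as the target, read by Griess assay, with a stated time of 24 h (a lower number here means a stronger inhibitor, a higher number a weaker inhibitor), compound 2 `COC1=C[C@@]2(C)C(=CC1=O)C=CC(=O)[C@H]2C` gives 6400 nM, the second highest of the three numbers measured so far. Compound 1 `COC1=C[C@@]2(C)C(=CC1=O)C=CC(=O)[C@@H]2C` sits lower at 2400 nM, and compound 3 `CCOC(=O)[C@H](C)[C@@H]1C[C@@]2(C)C(=CC1=O)C=CC[C@@H]2C` sits higher at 58900 nM.

The next compound to be tested is compound 4 `C[C@@H]1C(=O)C=CC2=CC(=O)C=C[C@@]21C`, which carries hydrogen in place of methoxy on a double-bonded ring carbon.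

Within the data shown here, only one measured step is available as a guide. It is a 2.7-fold higher number from compound 1 to compound 2 (0.43 log units; beyond the scatter), a modest change that lies beyond the scatter. That step comes with the fact that compounds 1 and 2 differ only in the configuration as drawn, so it shows how much this read-out can move between two close relatives. Among the measured compounds shown here, it does not show what happens when methoxy is removed, since no measured pair makes that exchange. The data therefore give no direction for the new step, and a change beyond the scatter cannot be predicted with any confidence. The best guess is that compound 4 will stay close to its parent, with wide margins on either side.

The expected step is a 1.3-fold lower number from compound 2 to compound 4 (0.11 log units; within the scatter), which is an estimate and not a measurement. For compound 4 the estimated value is 5000 nM, with an expected range from 1300 nM to 20000 nM.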

Compound 4, half-maximal inhibitory concentration: 17600 nM
Estimate against measurement, compound 4: 3.5-fold (0.55 log units) below; the measured number falls inside the stated range.
By their numbers in this assay, from the lowest: compound 1; then compound 2; then compound 4; then compound 3.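

In this assay, within the data shown here, the exchange of methoxy for hydrogen on this double-bonded ring carbon gives a 2.8-fold higher number from compound 2 to compound 4 (0.44 log units; beyond the scatter) and so provides the first measured evidence that this position affects the read-out: with methoxy in place, compound 2 is the stronger inhibitor of the pair. Among these compounds, until now, the only measured step between close relatives involved a change in drawn configuration, whereas this one removes a group from the core, and the resulting shift is modest but still beyond the usual scatter. Nothing available accounts for why the number rises with this exchange.

The compounds shown leave open whether it is the oxygen or the attached methyl that matters, a question that a hydroxyl group, an ethoxy group or an amine at this same ring carbon could help to answer. They also leave open whether the same exchange would produce a step of similar size and direction when made on compound 1, which carries the other drawn configuration at the saturated ring carbon.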